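Sulfonamide nitrogen substituent: cyclopentyl to tert-butyl

The source may hold more compounds than are shown below. What is called first, only, known or untested is meant among the compounds shown, and "the series" means these compounds.

Measured so far:
compound 1 `O=C(Nc1cccc(S(=O)(=O)C2CCCC2)n1)c1ccc(NCCO)cc1N1CCC2(CC1)CC2`: 177 nM
compound 2 `O=C(Nc1cccc(S(=O)(=O)C2CCCC2)c1)c1cccnc1N1CCCCC1`: 6350 nM
compound 3 `CC(C)(CO)Nc1ccc(C(=O)Nc2cccc(S(=O)(=O)NC3CCCC3)n2)c(N2CCC3(CC2)CC3)c1`: 48 nM

In a functional assay on OVCAR-3 cells (Homo sapiens) for activation, with a stated time of 24 h (on this read-out higher numbers stand for an effect only at larger amounts of compound and lower numbers for an effect already at smaller amounts), compound 3 gives the lowest number of the three; compound 1 sits nearest, beyond the scatter, and compound 2 furthest, also beyond the scatter, so compound 3 is the most active of the measured set.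

Compound 4 `CC(C)(C)NS(=O)(=O)c1cccc(NC(=O)c2ccc(NC(C)(C)CO)cc2N2CCC3(CC2)CC3)n1` has not yet been measured. It differs from compound 3 in one place: tert-butyl in place of cyclopentyl on a sulfonamide nitrogen. Both groups carry no donor and no acceptor, and only one heavy atom and a ring are lost, so no step beyond the scatter is expected in this assay in either direction.

For compound 4 the expected value in this assay is 65 nM, within 25 nM to 200 nM, which means an estimated step of a 1.4-fold higher number from compound 3 to compound 4 (0.13 log units; within the scatter).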

Compound 4, half-maximal effective concentration: 28 nM
The estimate for compound 4 lay 2.3-fold (0.37 log units) above the measured number, within the range that was stated.
By their numbers in this assay, from the lowest: compounds 4 and 3 (each within the scatter of the next); then compound 1; then compound 2.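

Replacing cyclopentyl with tert-butyl on the sulfonamide nitrogen gives a 1.7-fold lower number from compound 3 to compound 4 (0.23 log units; within the scatter) in this assay and leaves the read-out unchanged within the scatter. Within the data shown here, this position therefore accepts a carbon group without a ring as well as one with a ring, which the earlier compounds could not show. Nothing measured here accounts for this result.

Open, going by these compounds, is how this position responds to a much smaller group such as methyl. Also open, on these data alone, is how it responds to a group bearing a hydroxyl or an amine.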